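Carbamate alkyl chain variation on the shared core

A few compounds are considered here, and "the series" means these few. Any claim that something is new, unique, unknown or untested is made for them only; others in the source may bear on it.

Measured so far:
compound 1, `COc1ccc(C[C@@H]2[C@H](OC(=O)NC3CCN(Cc4ccccc4)CC3)[C@@H](O)CN2C(=O)c2cc(-c3ccc(Cl)cc3)oc2C(F)(F)F)cc1`: 8000 nM
compound 2, `CCOC(=O)N1C[C@H](O)[C@@H](OC(=O)NCc2ccccc2-c2ccccc2)[C@H]1Cc1ccc(OC)cc1`: 22000 nM

In a functional assay on HEK293 cells (Homo sapiens) for inhibition (on this read-out lower numbers stand for stronger inhibition and higher numbers for weaker inhibition), compound 1 gives 8000 nM. Compound 2 gives 22000 nM in this assay, the highest of the two numbers recorded; its nearest neighbour is compound 1, and that gap lies beyond the usual scatter. Among the compounds with values here, the two compounds differ in more than one place, so no single step connects them and only their two values can be compared.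

Compound 3, `COc1ccc(C[C@@H]2[C@H](OC(=O)NCc3ccccc3-c3ccccc3)[C@@H](O)CN2C(=O)OCC(C)C)cc1`, has not yet been measured. It differs from compound 2 by isopropyl in place of methyl on a saturated chain carbon bound to an oxygen next to a carbonyl group; read one bond further out, the change is ethoxycarbonyl to isobutoxycarbonyl. Within the data shown here, no measured pair isolates this kind of change, so there is no step to lean on. The expected step, given this, is a 1.4-fold lower number from compound 2 to compound 3 (0.14 log units; within the scatter), which is not expected to exceed the scatter in either direction, with at most a slight lean towards a lower number. Compound 3 is therefore estimated at 16000 nM in this assay, with a range from 5000 nM to 50000 nM.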

Compound 3, half-maximal inhibitory concentration: 11000 nM
Compound 3: the middle estimate sits 1.5-fold (0.16 log units) above what was measured; measured number inside the range.
By their numbers in this assay, from the lowest: compounds 1, 3 and 2 (each within the scatter of the next, the first and the last beyond it).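

Isopropyl in place of methyl on a saturated chain carbon bound to an oxygen next to a carbonyl group gives the first single-place step in the series, a 2.0-fold lower number from compound 2 to compound 3 (0.30 log units; within the scatter) in this assay. Read one bond further out, ethoxycarbonyl and isobutoxycarbonyl therefore cannot be told apart on this read-out, so this one change shows no effect at this position with the biphenyl-bearing carbamate held constant. No measured property of either group bears on this result.

Still open, from the compounds shown here alone, is how this position responds to groups that differ more from these two, such as a longer chain, a chain carrying an amine, or one carrying a carboxylic acid. The series also rests on a single step here, so whether the same change reads the same with a different carbamate on the shared core remains unresolved.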